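The source may hold more compounds than are shown below. What is called first, only, known or untested is meant among the compounds shown, and "the series" means these compounds.

Measured so far:
Compound 1 `CC(C(=O)NCc1ccc(C(F)(F)F)cc1N1CCC(Cc2ccc(F)cc2)CC1)c1ccc(NS(C)(=O)=O)c(F)c1` — 0.4 nM
Compound 2 `CC(C)COc1cc(C(F)(F)F)ccc1CNC(=O)C(C)c1ccc(NS(C)(=O)=O)c(F)c1` — 0.8 nM

Both compounds were run in an assay on CHO cells for antagonist activity at transient receptor potential cation channel subfamily V member 1 (Homo sapiens), read by FLIPR; on this read-out higher numbers stand for weaker inhibition and lower numbers for stronger inhibition. Compound 1 gives 0.4 nM, and compound 2 gives 0.8 nM. Compound 2 thus carries the higher of the two numbers, but the gap to compound 1 lies within the scatter, so the two cannot be separated on this read-out. Among the measured compounds shown here, no pair of measured compounds differing in a single place is available, so the series gives no direct reference for how large one change tends to be here.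

Compound 3 `CC(C(=O)NCc1ccc(C(F)(F)F)cc1Cl)c1ccc(NS(C)(=O)=O)c(F)c1` differs from compound 2 in one place: chloro in place of isobutoxy on an aromatic carbon. Both measured compounds carry a group larger than chloro at the varied position and both give low numbers; compound 3 carries only chloro there. Without a measured step to lean on, the expectation is a moderate rise in this assay, meaning weaker inhibition, most likely a little beyond the scatter rather than within it. Compound 3 is estimated at 4 nM, with an expected range from 1 nM to 20 nM. The expected step is a 5.0-fold higher number from compound 2 to compound 3 (0.70 log units; beyond the scatter).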

Compound 3, inhibition constant: 4 nM
Estimate against measurement, compound 3: no gap at the digits printed, and the stated range covers the measured number.
By their numbers in this assay, from the lowest: compounds 1 and 2 (each within the scatter of the next); then compound 3.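

In this assay, among the compounds shown here, chloro in place of isobutoxy on this aromatic carbon, which is meta to a trifluoromethyl group, gives a 5.0-fold higher number from compound 2 to compound 3 (0.70 log units; beyond the scatter) and is the only step so far that can be read. The position is therefore not indifferent to the group it carries, although the step is modest: with a single chlorine in place of the five heavy atoms of isobutoxy, compound 3 still gives 4 nM in this assay as a low number. No measurement at hand bears on the reason for this step, so it remains a description of the change and not an explanation of it.

The change removes carbon atoms and the oxygen with its hydrogen-bond acceptor together, so the compounds shown cannot separate what each contributes to the step. Open questions are what a methoxy group or a butyl chain without oxygen would give on this carbon, and whether plain hydrogen there would raise the number further than chloro does.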